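A second chloro on the benzyl ring of compound 3

A few compounds are considered here, and "the series" means these few. Any claim that something is new, unique, unknown or untested is made for them only; others in the source may bear on it.

Of the compounds shown here, three share one core and have been tested in a functional assay on MCF7 cells (Homo sapiens) for antiproliferative activity, read by MTT assay, with a stated time of 48 h, in the presence of a further agent that is not named here; on this read-out lower numbers stand for stronger inhibition of growth and higher numbers for weaker inhibition of growth. Compound 2 `O=C(NOCc1ccccc1)c1cn(-c2ccccc2)nc1-c1ccc(F)cc1` gives 15300 nM, and compound 3 `O=C(NOCc1ccccc1Cl)c1cn(-c2ccccc2)nc1-c1ccc(F)cc1` gives 11400 nM, the second highest of the three numbers. Compound 1 `Cc1ccc(-c2nn(-c3ccccc3)cc2C(=O)NOCc2ccc(Cl)cc2Cl)cc1`, which carries a 2,4-dichlorobenzyl group as well as a different ring on the core, gives 2310 nM. For the measured compounds named here, the only step measured in one place is a 1.3-fold lower number from compound 2 to compound 3 (0.13 log units; within the scatter). Compound 4 `O=C(NOCc1ccc(Cl)cc1Cl)c1cn(-c2ccccc2)nc1-c1ccc(F)cc1` differs from compound 3 by chloro in place of hydrogen on an aromatic carbon. Going by the values given here, compound 1 shows that a 2,4-dichlorobenzyl can sit beside a lower number, though it differs in two places, so no step is known for it. Compound 4 is therefore expected to show a 2.1-fold lower number from compound 3 to compound 4 (0.32 log units; beyond the scatter), a modest move towards lower numbers, with an estimate of 5500 nM in this assay, between 2000 nM and 15000 nM.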

Compound 4, concentration for 50% growth inhibition: 25300 nM
Beside the measured number, compound 4's estimate is 4.6-fold (0.66 log units) below it, outside the stated range (above it).
By their numbers in this assay, from the lowest: compound 1; then compounds 3, 2 and 4 (each within the scatter of the next, the first and the last beyond it).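

In this assay, the second chloro gives a 2.2-fold higher number from compound 3 to compound 4 (0.35 log units; beyond the scatter), so a 2,4-dichlorobenzyl group does not bring a lower number on this core. Measured against the plain benzyl group, the same compound shows a 1.7-fold higher number from compound 2 to compound 4 (0.22 log units; within the scatter). The large change comes instead with the other substitution, fluoro in place of methyl on an aromatic carbon, which gives an 11-fold higher number from compound 1 to compound 4 (1.04 log units; beyond the scatter).

No measurement shown here explains these steps. Going by these compounds, it remains open how a methoxy group or an amine would read at this place, para to a large group, and whether the fluoro-to-methyl step holds with other benzyl groups.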